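The source may report more compounds than this note shows. Statements on the series, on what has been measured and on what is new or still open speak of the compounds shown alone.

Measured compounds:
Compound 1 `C[C@H](O)C(=O)N1CCC(CCn2c(Sc3cc4c(cc3Br)CCO4)nc3c(N)ncnc32)CC1`, 11000 nM.
Compound 2 `Nc1ncnc2c1nc(Sc1cc3c(cc1Br)OCC3)n2CCC1CCN(C=O)CC1`, 86000 nM.
Compound 3 `Nc1ncnc2c1nc(Sc1cc3occc3cc1Br)n2CCC1CCN(C=O)CC1`, 1100 nM.

In a functional assay on NCI/ADR-RES cells (Homo sapiens) for inhibition, read by luminescence, with a stated time of 72 h (a lower number here means a stronger inhibitor, a higher number a weaker inhibitor), compound 2 gives the highest number of the three; compound 1 sits nearer to it and compound 3 furthest away. Compound 4 `Nc1ncnc2c1nc(Sc1cc3c(cc1Br)CCC3)n2CCC1CCN(C=O)CC1` is not yet measured. The change from compound 2 to compound 4 is a group of 10 heavy atoms (9 carbon, 1 bromine; one five-membered non-aromatic ring of carbon only, one six-membered aromatic ring of carbon only) in place of a group of 10 heavy atoms (8 carbon, 1 oxygen, 1 bromine; one five-membered non-aromatic ring with 1 hetero atom, one six-membered aromatic ring of carbon only), on a sulfur. Among the measured compounds shown here, the only measured step at this same sulfur, a 78-fold lower number from compound 2 to compound 3 (1.89 log units; beyond the scatter), swapped the same group for an aromatic one, a different kind of change, so it gives only a loose hint that this position tolerates alteration. For the measured compounds named here, with no closer precedent, a modest step is expected for compound 4, a 2.2-fold lower number from compound 2 to compound 4 (0.33 log units; beyond the scatter), and compound 4 is estimated at 40000 nM, within 10000 nM to 150000 nM.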

Compound 4, half-maximal inhibitory concentration: 230 nM
The estimate for compound 4 lay 170-fold (2.24 log units) above the measured number, and the stated range ends above it.
By their numbers in this assay, from the lowest: compound 4; then compound 3; then compound 1; then compound 2.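

In this assay, the 6-bromo-2,3-dihydro-1H-inden-5-yl group on the sulfur gives a 370-fold lower number from compound 2 to compound 4 (2.57 log units; beyond the scatter) and so shows that swapping one ring oxygen for carbon can matter greatly here. A non-aromatic five-membered ring can also do better than an aromatic one, since replacing 5-bromo-1-benzofuran-6-yl gives a 4.8-fold lower number from compound 3 to compound 4 (0.68 log units; beyond the scatter) in the same assay. Nothing available explains these steps. Still open, going by these compounds, is whether a ring nitrogen, as in an amine, would behave like the oxygen or the carbon. Replacing the bromine with chlorine, or the five-membered ring with a six-membered carbon ring, is also untested among these compounds.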